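Cyclobutyl for ethyl on a bromine-bearing compound

The source may report more compounds than this note shows. Statements on the series, on what has been measured and on what is new or still open speak of the compounds shown alone.

Values in an ADME assay on Vero cells (Chlorocebus sabaeus) for cytotoxicity, read by CellTiter-Glo, with a stated time of 72 h; a lower number here means that less compound is tolerated, a higher number that more compound is tolerated:
Compound 1 `[O-][n+]1nc(NC2CCC2)[n+]([O-])c2ccccc21`: 8.9 ug/mL
Compound 2 `[O-][n+]1nc(NC2CCC2)[n+]([O-])c2ccc(F)cc21`: 1.6 ug/mL
Compound 3 `CCNc1n[n+]([O-])c2cc(Br)ccc2[n+]1[O-]`: 4.2 ug/mL

Compound 3 stands second highest of the three. The highest number belongs to compound 1 at 8.9 ug/mL. The lowest number belongs to compound 2 at 1.6 ug/mL. Both gaps to compound 3 lie beyond the scatter. Compound 4 `[O-][n+]1nc(NC2CCC2)[n+]([O-])c2ccc(Br)cc21` keeps the bromine of compound 3 and differs from it in one place: cyclobutyl in place of ethyl on a nitrogen on an aromatic ring. The change is thus ethylamino to cyclobutylamino.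

Among the measured compounds shown here, no measured step makes this change, so the evidence is indirect. For the measured compounds named here, the only step available is a 5.6-fold lower number from compound 1 to compound 2 (0.75 log units; beyond the scatter), a modest one beyond the scatter, with fluoro in place of hydrogen on an aromatic carbon. It shows how far the number can move between two compounds that both carry cyclobutyl, but it does not isolate the effect of cyclobutyl itself. Those two compounds also lie on either side of compound 3, which gives no firm direction. A slight lean downward rests on compound 2, the other halogen-bearing compound with cyclobutyl, at 1.6 ug/mL. The expected change is a 1.4-fold lower number from compound 3 to compound 4 (0.15 log units; within the scatter), which would not go beyond the scatter. For compound 4 the estimated value is 3 ug/mL, with an expected range from 1 ug/mL to 8 ug/mL.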

Compound 4, half-maximal cytotoxic concentration: 3.8 ug/mL
Compound 4: middle estimate off by 1.3-fold (0.10 log units), on the low side; the range from low to high includes it.
By their numbers in this assay, from the lowest: compound 2; then compounds 4 and 3 (each within the scatter of the next); then compound 1.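

In this assay, the change from ethylamino to cyclobutylamino with bromine held in place gives a 1.1-fold lower number from compound 3 to compound 4 (0.04 log units; within the scatter) and so stays inside the usual scatter. Among the compounds shown here, this is the first direct reading of the change on a nitrogen on an aromatic ring, and on these bromine-bearing compounds ethyl and cyclobutyl cannot be told apart. With cyclobutyl held constant, the substituent on the aromatic carbon does move the number: bromo in place of fluoro gives a 2.4-fold higher number from compound 2 to compound 4 (0.38 log units; beyond the scatter) and bromo in place of hydrogen gives a 2.3-fold lower number from compound 1 to compound 4 (0.37 log units; beyond the scatter) and both steps lie beyond the scatter, leaving the bromo compound apart from the other two.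

The compounds shown leave open whether ethyl and cyclobutyl would also read alike with fluoro or hydrogen on that carbon, and how a longer chain or a chain ending in an amine would read on the same nitrogen. Nothing available here accounts for any of these numbers.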